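Chloro position on the benzoyl group of the dimethoxy core

This account rests on a few compounds, and the source may have more. Where it says the series, first, only, none or still open, it means among the compounds named here.

Compound 1 `COc1cc2ncnc(NNC(=S)NC(=O)c3ccccc3Cl)c2cc1OC` carries a 2-chlorophenyl on the carbonyl carbon. In a functional assay on MCF7 cells (Homo sapiens) for cytotoxicity, read by MTT assay, with a stated time of 72 h (on this read-out lower numbers stand for stronger inhibition and higher numbers for weaker inhibition), compound 1 gives 23100 nM, the highest of the three numbers. The nearest measured compound is compound 2 `O=C(NC(=S)NNc1ncnc2ccccc12)c1ccccc1`, which in this assay gives 5960 nM, beyond the scatter from compound 1. Furthest is compound 3 `O=C(NC(=S)NNc1ncnc2ccccc12)c1cccc(Cl)c1`, which in this assay gives 3540 nM. Compound 4 `COc1cc2ncnc(NNC(=S)NC(=O)c3cccc(Cl)c3)c2cc1OC` differs from compound 1 by 3-chlorophenyl in place of 2-chlorophenyl on a carbonyl carbon. Among the compounds with values here, no measured step moves a chloro from one ring position to another. Within the data shown here, the only step that bears on the chlorophenyl, a 1.7-fold lower number from compound 2 to compound 3 (0.23 log units; within the scatter), concerns the 3-chlorophenyl on the unsubstituted core and is within the scatter. Compound 4 is therefore expected to show a small step of a 1.9-fold lower number from compound 1 to compound 4 (0.28 log units; within the scatter) towards a lower number in this assay, on the unproven assumption that the 3-chlorophenyl behaves on the dimethoxy core as it does in compound 3. The estimate for compound 4 in this assay is 12000 nM, with a range from 5000 nM to 30000 nM.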

Compound 4, half-maximal inhibitory concentration: 11500 nM
Compound 4: middle estimate off by 1.0-fold (0.02 log units), on the high side, within the range that was stated.
By their numbers in this assay, from the lowest: compounds 3, 2, 4 and 1 (each within the scatter of the next, the first and the last beyond it).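

This is the first listed step that changes only where the chloro sits on the phenyl group, with the rest of the molecule held constant. In this assay, 3-chlorophenyl in place of 2-chlorophenyl on a carbonyl carbon gives a 2.0-fold lower number from compound 1 to compound 4 (0.30 log units; within the scatter), so this assay does not separate the two chlorophenyl groups on the core of compound 1, and the earlier step on the other core could not show this. No supporting measurement is available to explain the size of this step.

Going by these compounds, it remains open how an unsubstituted phenyl would read on this carbonyl carbon of the same core, since that comparison would show what either chlorophenyl contributes there. Also open, on these data alone, is whether a group of a different kind at that place, such as an aminophenyl or a carboxyphenyl, would give a step beyond the scatter.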